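The source may hold more compounds than are shown below. What is called first, only, known or untested is meant among the compounds shown, and "the series" means these compounds.

Compound 1 `COc1cc(C=C(C(=O)/C=C/c2cccc(OC)c2OC)C(=O)/C=C/c2cccc(OC)c2OC)ccc1O`: 130 nM
Compound 2 `COc1ccc(C=C(C(=O)/C=C/c2cccc(OC)c2OC)C(=O)/C=C/c2cccc(OC)c2OC)cc1OC`: 170 nM

Both values come from a functional assay on A549 cells (Homo sapiens) for antiproliferative activity, read by sulforhodamine B assay, with a stated time of 48 h; on this read-out higher numbers stand for weaker inhibition and lower numbers for stronger inhibition. Compound 2, at 170 nM, sits within the scatter of compound 1, at 130 nM, so the two cannot be told apart on these numbers.

Compound 3 `COc1cc(OC)c(C=C(C(=O)/C=C/c2cccc(OC)c2OC)C(=O)/C=C/c2cccc(OC)c2OC)c(OC)c1` has not yet been measured. It differs from compound 2 at one place: 2,4,6-trimethoxyphenyl in place of 3,4-dimethoxyphenyl on a double-bonded chain carbon bound to a double-bonded chain carbon. In words, 2,4,6-trimethoxyphenyl stands in place of 3,4-dimethoxyphenyl on a double-bonded chain carbon bound to a double-bonded chain carbon.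

Within the data shown here, only one measured step offers any guidance: a 1.3-fold higher number from compound 1 to compound 2 (0.12 log units; within the scatter). It comes from a methyl in place of hydrogen on an oxygen on an aromatic ring, a smaller edit than the one now in question. Among the measured compounds shown here, no measured compound carries 2,4,6-trimethoxyphenyl, so the evidence is thin and the range must stay wide. In this assay, no shift beyond the scatter is firmly expected, with only a slight lean toward a higher number. The expected move is a 1.5-fold higher number from compound 2 to compound 3 (0.17 log units; within the scatter). For compound 3 the estimated value is 250 nM, with an expected range of 70 nM to 900 nM.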

Compound 3, half-maximal inhibitory concentration: 630 nM
Compound 3: middle estimate off by 2.5-fold (0.40 log units), on the low side, and the stated range covers the measured number.
By their numbers in this assay, from the lowest: compounds 1 and 2 (each within the scatter of the next); then compound 3.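

In this assay, the group on this double-bonded chain carbon proves able to change the read-out: 2,4,6-trimethoxyphenyl in place of 3,4-dimethoxyphenyl gives a 3.7-fold higher number from compound 2 to compound 3 (0.57 log units; beyond the scatter), whereas the earlier methyl-for-hydrogen edit stayed within the scatter. Against the 4-hydroxy-3-methoxyphenyl group, the same ring gives a 4.8-fold higher number from compound 1 to compound 3 (0.69 log units; beyond the scatter), so both comparisons agree that this change weakens inhibition, and the position is not indifferent to what the aromatic ring carries. No supporting measurement is available here to explain why this happens.

The step changes two things at once, the number of methoxy groups and where they stand on the ring, so these compounds cannot show which of the two matters, or whether both do. It also remains open how this position would respond to a different kind of group, such as an amine or a carboxylic acid on the aromatic ring in place of the methoxy groups, since every ring shown here carries only methoxy groups or a methoxy group and a hydroxyl.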